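The source may report more compounds than this note shows. Statements on the series, on what has been measured and on what is new or still open speak of the compounds shown alone.

Measured in a functional assay on HCT-116 cells (Homo sapiens) for antiproliferative activity, read by MTT assay, with a stated time of 72 h; on this read-out higher numbers stand for weaker inhibition and lower numbers for stronger inhibition:
compound 1 `Nc1nc(N)c2cc(CSC(=S)N3CCN(c4ccccc4)CC3)ccc2n1`: 4120 nM
compound 2 `COc1ccc(N2CCN(C(=S)SCc3ccc4nc(N)nc(N)c4c3)CC2)cc1`: 2270 nM
compound 3 `Cc1ccccc1N1CCN(C(=S)SCc2ccc3nc(N)nc(N)c3c2)CC1`: 11800 nM

These three compounds share one core and differ only in the aromatic group on an amine nitrogen in a ring. Among them, compound 3 has the highest number, 11800 nM, which makes it the weakest of the three in this assay.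

The next compound, compound 4 `Cc1ccc(N2CCN(C(=S)SCc3ccc4nc(N)nc(N)c4c3)CC2)c(C)c1`, changes 2-methylphenyl to 2,4-dimethylphenyl (methyl in place of hydrogen on an aromatic carbon). This is methyl in place of hydrogen on an aromatic carbon, meta to a methyl group and para to a large group.

Among the compounds with values here, two measured steps bear on this change. Adding a methyl gave a 2.9-fold higher number from compound 1 to compound 3 (0.46 log units; beyond the scatter), but that step produced the 2-methylphenyl group, so its methyl does not stand where the new one will. Adding methoxy gave a 1.8-fold lower number from compound 1 to compound 2 (0.26 log units; within the scatter), and that step produced the 4-methoxyphenyl group, although methoxy is a different group from methyl. Within the data shown here, neither step is an exact match, and no measured compound carries two groups on this ring. No step beyond the scatter is therefore expected in this assay, in either direction.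

This estimate means an expected 1.3-fold lower number from compound 3 to compound 4 (0.12 log units; within the scatter). For compound 4 the estimated value is 9000 nM, with an expected range from 3500 nM to 22000 nM.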

Compound 4, half-maximal inhibitory concentration: 4070 nM
Estimate against measurement, compound 4: 2.2-fold (0.34 log units) above, within the range that was stated.
By their numbers in this assay, from the lowest: compounds 2, 4 and 1 (each within the scatter of the next); then compound 3.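

In this assay, a second methyl on the aromatic ring, para to a large group and meta to the methyl already there, gives a 2.9-fold lower number from compound 3 to compound 4 (0.46 log units; beyond the scatter). This shows that the number responds to a change at this position, and that the rise seen earlier with the first methyl, a 2.9-fold higher number from compound 1 to compound 3 (0.46 log units; beyond the scatter), does not persist once the second methyl is present. The 2,4-dimethylphenyl group cannot be told apart from the plain phenyl group, with a 1.0-fold lower number from compound 1 to compound 4 (0.01 log units; within the scatter), or from the 4-methoxyphenyl group, with a 1.8-fold higher number from compound 2 to compound 4 (0.25 log units; within the scatter), so a ring with two methyl groups can sit in the same range as these simpler rings.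

Nothing shown explains why the added methyl has this effect on the number. The compounds shown leave open what a lone methyl in this place would do on a ring without the other methyl, and whether a different group there, such as a chlorine atom, an amine or a carboxylic acid, would give a similar number.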